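Vero cytotoxicity notes: methyl added on the ring-borne nitrogen

The source may report more compounds than this note shows. Statements on the series, on what has been measured and on what is new or still open speak of the compounds shown alone.

compound 1 `CN(CC1CCCCC1)N1CCN(c2nc(=O)c3cc(C(F)(F)F)cc([N+](=O)[O-])c3s2)CC1` — > 64 ug/mL (a limit)
compound 2 `O=c1nc(N2CCN(Nc3ccc(OC(F)(F)F)cc3)CC2)sc2c([N+](=O)[O-])cc(C(F)(F)F)cc12` — > 64 ug/mL (a limit)

In an ADME assay on Vero cells (Chlorocebus sabaeus) for cytotoxicity, read by MTT assay, with a stated time of 72 h (a lower number here means that less compound is tolerated, a higher number that more compound is tolerated), compound 1 reaches only the limit of the assay, > 64 ug/mL. Compound 2 likewise gives only a limit in this assay, > 64 ug/mL. Among the compounds with values here, both values sit at the limit of > 64 ug/mL in this assay, at which 2 of the 2 values shown sit, so the single measured step, a step that the two limits leave unreadable from compound 1 to compound 2, cannot be read in size or direction. Compound 2 therefore stands at the top of the range shown, with no numeric value known for it.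

Compound 3 `CN(c1ccc(OC(F)(F)F)cc1)N1CCN(c2nc(=O)c3cc(C(F)(F)F)cc([N+](=O)[O-])c3s2)CC1` differs from compound 2 by methyl in place of hydrogen on a nitrogen on an aromatic ring. Within the data shown here, no measured step concerns this change, and the only step available is unreadable, so no size can be taken from it. The expectation rests solely on both measured compounds sitting at the limit. Compound 3 is expected to show a step that the limit leaves unreadable from compound 2 to compound 3, no step beyond the scatter. Compound 3 is thus estimated at 80 ug/mL, range 40 ug/mL to 160 ug/mL, most likely reported again only as a limit.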

Compound 3, half-maximal cytotoxic concentration: > 64 ug/mL
Compound 3: a limit, no number (the forecaster's own chance of this, stated with the estimate: 80%); the middle value is on the limit's open side.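

In this assay compound 3 again gives only a limit, > 64 ug/mL, so the steps to it from compound 1 and compound 2 cannot be read in size or direction: the limit of > 64 ug/mL in this assay, at which 3 of the 3 values shown sit. The compounds shown leave open the actual tolerated concentration of all three, and whether methyl in place of hydrogen on that nitrogen changes anything in this assay.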